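From compound 3 to compound 4: a phenoxy swap

The source may hold more compounds than are shown below. What is called first, only, known or untested is meant among the compounds shown, and "the series" means these compounds.

In a physicochemical assay for lipophilicity, using the shake flask method, in phosphate buffer, measured as octanol-water partition, with a stated time of 30 min, at pH 7.4 (a higher number here means a more lipophilic compound, a lower number a more polar compound), compound 3 (`O=C1c2ccccc2CN1c1cnc(NCc2c(F)ccc3c2CCO3)n2cnnc12`) gives 2.7, the middle of three measured values. Compound 2 (`CN(c1ncco1)c1cnc(NCc2c(F)ccc3c2CCO3)n2cnnc12`) gives 2.1 and compound 1 (`O=C(Nc1ccccc1)c1cnc(NCc2c(F)ccc3c2CCO3)n2cnnc12`) gives 4.1. Compound 4 (`Fc1ccc2c(c1CNc1ncc(Oc3ccccc3)c3nncn13)CCO2`) keeps the shared core but carries phenoxy: a group of 7 heavy atoms (6 carbon, 1 oxygen; one six-membered aromatic ring of carbon only) in place of a group of 10 heavy atoms (8 carbon, 1 nitrogen, 1 oxygen; one five-membered non-aromatic ring with 1 hetero atom, one six-membered aromatic ring of carbon only), on an aromatic carbon. For the measured compounds named here, no measured step involves phenoxy, so the guidance is indirect. The nearest comparison is compound 1, whose group also holds a single six-membered aromatic ring of carbon only, and the number falls by a large step, a number 1.40 log units lower from compound 1 to compound 3 (beyond the scatter). The other step, a number 0.60 log units higher from compound 2 to compound 3 (beyond the scatter), is modest. A modest rise is therefore expected, an estimated a number 0.70 log units higher from compound 3 to compound 4 (beyond the scatter). The expected value for compound 4 is 3.4, with an estimated range of 2.8 to 4.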

Compound 4, distribution coefficient: 3.5
For compound 4 the middle estimate is 0.10 log units below the measured one; the range from low to high includes it.
By their numbers in this assay, from the lowest: compound 2; then compound 3; then compound 4; then compound 1.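

In this assay, the ring count alone does not set the number at this aromatic carbon: compound 1 and compound 4 each hold one six-membered aromatic ring of carbon only, yet phenoxy and phenylcarbamoyl differ (a number 0.60 log units lower from compound 1 to compound 4 (beyond the scatter)). Phenoxy also stands above the two other groups (a number 0.80 log units higher from compound 3 to compound 4 (beyond the scatter); a number 1.40 log units higher from compound 2 to compound 4 (beyond the scatter)). Still open, as far as these compounds go, is where a smaller group such as methoxy, or an amine or a carboxylic acid, would fall at this place. No measurement shown here gives a reason for these differences.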